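This account rests on a few compounds, and the source may have more. Where it says the series, first, only, none or still open, it means among the compounds named here.

Of the compounds shown here, three of one shared core have been measured in an assay on isolated protein for inhibition of ubiquitin carboxyl-terminal hydrolase 7 (Homo sapiens), with stated times of 30 min and 2 h; a lower number here means a stronger inhibitor, a higher number a weaker inhibitor. Compound 1 `Cn1nc2c(=O)n(CC3(O)CCN(Cc4ccc(-c5n[nH]c(=O)o5)cc4Cl)CC3)cnc2c1-c1ccc(CN)cc1` gives 171 nM, and compound 2 `Cn1nc2c(=O)n(CC3(O)CCN(Cc4ccc(-c5ccco5)cc4Cl)CC3)cnc2c1-c1ccc(OC(F)F)cc1` gives 179 nM. Compound 3 `Cn1nc2c(=O)n(CC3(O)CCN(Cc4ccc(-c5ccsc5)cc4Cl)CC3)cnc2c1-c1ccc(CN)cc1` gives 59.5 nM, the lowest of the three numbers, with both others lying beyond the scatter above it. Going by the values given here, the one step available between compounds differing in a single place is a 2.9-fold lower number from compound 1 to compound 3 (0.46 log units; beyond the scatter), a modest gain from exchanging one five-membered ring for another.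

Compound 4 `Cn1nc2c(=O)n(CC3(O)CCN(Cc4ccc(-c5ccco5)cc4Cl)CC3)cnc2c1-c1ccc(CN)cc1` is the next step from compound 3: furan-2-yl in place of thiophen-3-yl on an aromatic carbon. Among the compounds with values here, no measured pair shows this particular exchange directly. The furan-2-yl group is carried by compound 2, which differs from compound 4 elsewhere as well; the value of compound 2, 179 nM, offers only indirect guidance. Both rings are five-membered with one hetero atom, so the step is expected to be small, with a slight drift toward a higher number allowed for. Compound 4 is therefore estimated at 90 nM, within a range of 40 nM to 200 nM, which would mean an expected step of a 1.5-fold higher number from compound 3 to compound 4 (0.18 log units; within the scatter).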

Compound 4, half-maximal inhibitory concentration: 18.1 nM
Compound 4: middle estimate off by 5.0-fold (0.70 log units), on the high side; the whole stated range lies above it.
By their numbers in this assay, from the lowest: compound 4; then compound 3; then compounds 1 and 2 (each within the scatter of the next).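

On the aromatic carbon para to a large group, the identity of a five-membered aromatic ring matters even when heavy-atom, donor and acceptor counts stay the same: in this assay, furan-2-yl in place of thiophen-3-yl gives a 3.3-fold lower number from compound 3 to compound 4 (0.52 log units; beyond the scatter), and furan-2-yl in place of the ring with three hetero atoms gives a 9.4-fold lower number from compound 1 to compound 4 (0.98 log units; beyond the scatter). Going by these compounds alone, with furan-2-yl held fixed, the other place can now be read for the first time, as aminomethyl in place of difluoromethoxy gives a 9.9-fold lower number from compound 2 to compound 4 (1.00 log units; beyond the scatter). Nothing at hand accounts for either change.

As far as these compounds go, the step from compound 3 to compound 4 exchanges both the hetero atom and the point of attachment, so it remains open which of the two matters, a question that thiophen-2-yl or furan-3-yl would separate. Also open, from the compounds shown here alone, is how aminomethyl compares with a hydroxymethyl group or a carboxylic acid in that place.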